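The source may report more compounds than this note shows. Statements on the series, on what has been measured and on what is new or still open speak of the compounds shown alone.

Compound 1 `CC1=C(C(=O)OCC(C)C)C(c2ccoc2)NC(=O)N1C`: 4%
Compound 2 `CC1=C(C(=O)OC(C)(C)C)C(c2ccoc2)NC(=O)N1C`: 21%

In an assay on membranes from CHO cells for displacement of a labelled ligand from adenosine receptor A1 (Homo sapiens), read by scintillation counting, with a stated time of 60 min, tested at 1 uM (on this read-out lower numbers stand for less inhibition and higher numbers for more inhibition at the one concentration tested (going by the name of the read-out)), compound 1 gives 4%, while compound 2 gives 21%. Compound 2 thus stands highest of the two numbers, and the step of a number 17 percentage points higher from compound 1 to compound 2 (beyond the scatter) is beyond the scatter, though modest in size. Compound 3 `CC1=C(C(=O)OCc2ccccc2)C(c2ccoc2)NC(=O)N1C` differs from compound 2 in one place: benzyl in place of tert-butyl on an oxygen next to a carbonyl group. Within the data shown here, no measured step bears directly on this exchange of benzyl for tert-butyl; the only step measured, from isobutyl to tert-butyl on the same oxygen, was a number 17 percentage points higher from compound 1 to compound 2 (beyond the scatter), which shows that the group on this oxygen can move the read-out somewhat, but it gives no direction for a benzyl group. The expectation for compound 3 in this assay is therefore a step of about a number 6 percentage points lower from compound 2 to compound 3 (within the scatter), that is, nothing clearly beyond the scatter, with the number staying in the low range that both measured compounds occupy. Compound 3 is estimated at 15%, with a range from 0% to 40%.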

Compound 3, a percentage reported as inhibition, at one concentration (the size of the read-out at that concentration, not a potency): 51%
Estimate against measurement, compound 3: 36 percentage points below; measured number outside the range, above it.
By their numbers in this assay, from the lowest: compound 1; then compound 2; then compound 3.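

In this assay, benzyl in place of tert-butyl on an oxygen next to a carbonyl group gives a number 30 percentage points higher from compound 2 to compound 3 (beyond the scatter), and the comparison with the isobutyl compound gives a number 47 percentage points higher from compound 1 to compound 3 (beyond the scatter), which is the largest change among the compounds shown. Among these compounds, the earlier pair showed only that exchanging one saturated group for another on this oxygen could shift a low number, whereas this result shows that a group with one six-membered aromatic ring of carbon only can lift the number well clear of both, with both new steps beyond the scatter. Nothing given here explains why benzyl behaves in this way.

Benzyl differs from tert-butyl in both its ring and its count of heavy atoms, 7 against 4, so the compounds shown cannot separate the contribution of the aromatic ring from that of the larger group. From the compounds shown here alone, it remains open whether a cyclohexylmethyl group would give a similar number, and whether a phenethyl group or a benzyl group carrying a chlorine or a methoxy group would raise or lower it.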